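The compounds below may be only part of what the source reports. "The series", "measured", "known", "first", "only" and "open" are said of these compounds alone.

In a functional assay on HeLa cells (Homo sapiens) for antiproliferative activity, read by MTT assay, with a stated time of 48 h (on this read-out higher numbers stand for weaker inhibition and lower numbers for stronger inhibition), compound 1 (`O=C(/C=C/c1ccccc1)Nc1cc2c(Nc3ccc(Cl)c(Cl)c3)ncnc2s1`) gives 430 nM, compound 2 (`COc1ccc(/C=C/C(=O)Nc2cc3c(Nc4cc(Cl)cc(Cl)c4)ncnc3s2)cc1`) gives 43300 nM and compound 3 (`O=C(/C=C/c1ccccc1)Nc1cc2c(Nc3cccc(Cl)c3F)ncnc2s1`) gives 34900 nM. Compound 3 thus lies within the scatter of compound 2, and both numbers are far higher than that of compound 1. Compound 4 (`O=C(/C=C/c1ccccc1)Nc1cc2c(Nc3cc(Cl)cc(Cl)c3)ncnc2s1`) carries 3,5-dichlorophenyl in place of 3-chloro-2-fluorophenyl on a nitrogen on an aromatic ring. Within the data shown here, the one measured step at this place is large, an 81-fold higher number from compound 1 to compound 3 (1.91 log units; beyond the scatter), so a change here can matter in this assay. Compound 2 holds the same 3,5-dichlorophenyl but differs elsewhere too, and its 43300 nM speaks against a large gain. The expected change is modest, a 2.3-fold lower number from compound 3 to compound 4 (0.37 log units; beyond the scatter), toward a lower number. Compound 4 is estimated at 15000 nM, with an expected range of 2500 nM to 60000 nM.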

Compound 4, half-maximal inhibitory concentration: 4 nM
Compound 4: middle estimate off by 3800-fold (3.57 log units), on the high side; the whole stated range lies above it.
By their numbers in this assay, from the lowest: compound 4; then compound 1; then compounds 3 and 2 (each within the scatter of the next).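

In this assay the group on the nitrogen decides the outcome: 3,5-dichlorophenyl in place of 3-chloro-2-fluorophenyl gives the first sharp drop (an 8700-fold lower number from compound 3 to compound 4 (3.94 log units; beyond the scatter)), and it also outdoes 3,4-dichlorophenyl (a 110-fold lower number from compound 1 to compound 4 (2.03 log units; beyond the scatter)). That group does not suffice alone, since compound 2 carries it too, and hydrogen in place of methoxy on an aromatic carbon accounts for a step of similar size (an 11000-fold lower number from compound 2 to compound 4 (4.03 log units; beyond the scatter)). No measurement shown explains either effect. On these data alone, whether 3,5-dibromophenyl on that nitrogen, or fluorine or a nitrile in place of the methoxy, would keep so low a number remains open.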